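Swapping the Ring on the Carbonyl Carbon

The source may report more compounds than this note shows. Statements on the series, on what has been measured and on what is new or still open speak of the compounds shown alone.

Measured so far:
compound 1 `COc1cc(-c2cc(/C=C/C(=O)c3ccc(N)cc3)[nH]n2)cc(OC)c1OC`: 15%
compound 2 `COc1ccc(-c2cc(/C=C/C(=O)c3ccc(OC)c(OC)c3)[nH]n2)cc1`: 15%
compound 3 `COc1ccc(-c2cc(/C=C/C(=O)c3ccc(N)cc3)[nH]n2)cc1`: 9%

In a functional assay on NCI/ADR-RES cells (Homo sapiens) for cytotoxicity, read by sulforhodamine B assay, with a stated time of 48 h, tested at 10 uM (on this read-out lower numbers stand for a stronger effect and higher numbers for a weaker effect at the one concentration tested), compound 1 gives 15%, level with compound 2 at the digits shown, and the two together stand highest of the three numbers. Compound 3 gives 9%, a difference from compound 1 that stays within the scatter, so no order can be read between any of these three.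

Compound 4 `COc1ccc(C(=O)/C=C/c2cc(-c3cc(OC)c(OC)c(OC)c3)n[nH]2)cc1OC` is not yet measured. It differs from compound 1 in one place: 3,4-dimethoxyphenyl in place of 4-aminophenyl on a carbonyl carbon. A similar pairing already exists among the measured compounds, since compound 3 carries the aminophenyl and compound 2 the dimethoxyphenyl on the same carbonyl carbon, and compound 2 gives 15% while compound 3 gives 9%, values that lie within the scatter of each other. On that basis the step from compound 1 to compound 4 is expected to be a number 3 percentage points higher from compound 1 to compound 4 (within the scatter), no change beyond the scatter. Compound 4 is therefore estimated at 18%, ranging from 8% to 30%.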

Compound 4, a percentage reported as activity, at one concentration (the size of the read-out at that concentration, not a potency): 10%
Estimate against measurement, compound 4: 8 percentage points above; low and high end bracket the measured number.
By their numbers in this assay, from the lowest: compounds 3, 4, 1 and 2 (each within the scatter of the next).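

In this assay, placing 3,4-dimethoxyphenyl in place of 4-aminophenyl on a carbonyl carbon gives a number 5 percentage points lower from compound 1 to compound 4 (within the scatter) on the core of compound 1. Going by these compounds alone, this is the first direct comparison of these two groups on that core, and it shows that the position accepts a group with more heavy atoms and no hydrogen-bond donor without a change beyond the scatter. Compound 3 and compound 2 carry the same two groups on another core and also lie within the scatter of each other, so neither pair separates the two groups. No measurement at hand accounts for this result.

As far as these compounds go, it remains open whether a carboxylic acid or a longer alkyl chain in place of these rings on the carbonyl carbon would move the number beyond the scatter. Each compound also has a reading at only one concentration, so these numbers give no potency.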